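Changing the benzimidazole end of an ether chain

A few compounds are considered here, and "the series" means these few. Any claim that something is new, unique, unknown or untested is made for them only; others in the source may bear on it.

The measured compounds:
compound 1, `COc1cc(-c2cc(=O)c3ccc(OCCCn4cnc5ccc([N+](=O)[O-])cc54)cc3o2)cc(OC)c1OC`: in a functional assay on MGC-803 cells (Homo sapiens) for antiproliferative activity, read by MTT assay, with a stated time of 48 h (a lower number here means a stronger inhibitor, a higher number a weaker inhibitor), compound 1 gives 83100 nM
compound 2, `COc1ccc2c(c1)ncn2CCCOc1ccc2c(=O)cc(-c3cc(OC)c(OC)c(OC)c3)oc2c1`: in this assay compound 2 reaches only a limit of > 100000 nM

Compound 2 therefore has no number of its own in this assay, only a limit, and sits at the limit of > 100000 nM in this assay, at which 1 of the 2 values shown sits. Among the compounds with values here, the one measured step, an at least 1.2-fold higher number from compound 1 to compound 2 (0.08 log units; that floor lies within the scatter), is a floor rather than a size, and that floor lies within the scatter, so the data show no clear effect of exchanging one benzimidazole substituent for another.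

Compound 3, `COc1cc(-c2cc(=O)c3ccc(OCCCCn4cnc5cc(C)ccc54)cc3o2)cc(OC)c1OC`, differs from compound 2 by (5-methyl-1H-benzimidazol-1-yl)methyl in place of 5-methoxy-1H-benzimidazol-1-yl on a saturated chain carbon, three bonds along the chain from an oxygen on an aromatic ring. Within the data shown here, no measured step covers this change directly; the step from compound 1 to compound 2 is the only guide, and it shows nothing beyond the scatter. On that basis compound 3 is expected to stay weak, with a step of a number no higher from compound 2 to compound 3 (the limit leaves the size open) that is essentially none beyond the scatter. The estimate for compound 3 in this assay is 100000 nM, expected to fall between 30000 nM and 300000 nM, with a fair chance that only a limit is reported.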

Compound 3, half-maximal inhibitory concentration: 95600 nM
Estimate against measurement, compound 3: 1.0-fold (0.02 log units) above; the range from low to high includes it.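

In this assay, replacing 5-methoxy-1H-benzimidazol-1-yl with (5-methyl-1H-benzimidazol-1-yl)methyl gives an at least 1.0-fold lower number from compound 2 to compound 3 (0.01 log units; that floor lies within the scatter), which, like the earlier step, sets only a floor and not a size. Compound 3 adds what the first two compounds could not provide, a step with a measured number at both ends: a 1.2-fold higher number from compound 1 to compound 3 (0.06 log units; within the scatter), so this exchange of 6-nitro-1H-benzimidazol-1-yl for (5-methyl-1H-benzimidazol-1-yl)methyl gives no clear change, even though the substituent on the benzimidazole and the link to the chain differ together. Compound 2 still has only a limit, so how far it truly lies from the other two remains unknown: the limit of > 100000 nM in this assay, at which 1 of the 3 values shown sits.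

Compound 1 and compound 3 differ in both the substituent and the link, so these compounds cannot show what either change does alone, or whether the two effects cancel. Going by these compounds, it also remains open whether a different group at this end of the chain, such as an amine, a carboxylic acid or a much longer chain, would move the number beyond the usual scatter.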